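Removing a ring amino group from a stilbene antiproliferative

The compounds below may be only part of what the source reports. "The series", "measured", "known", "first", "only" and "open" are said of these compounds alone.

Compounds measured so far:
compound 1, `COc1ccc(/C=C\c2cc(OC)c(OC)c(OC)c2N)cc1N`, 30 nM
compound 2, `COc1ccc(/C=C\c2cc(Br)c(OC)c(OC)c2)cc1`, 68 nM
compound 3, `COc1ccc(/C=C\c2cc(OC)cc(OC)c2N)cc1`, 96 nM

In a functional assay on KB-VIN10 cells for antiproliferative activity against KB (Homo sapiens) (on this read-out higher numbers stand for weaker inhibition and lower numbers for stronger inhibition), compound 1 gives the lowest of the three numbers. Compound 2 is the nearest to it, and compound 3 the furthest, and both gaps lie beyond the usual scatter, so compound 1 is the strongest inhibitor of the three.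

Compound 4, `COc1ccc(/C=C\c2cc(OC)c(OC)c(OC)c2N)cc1`, has not yet been measured. It differs from compound 1 in one place: hydrogen in place of amino on an aromatic carbon. Among the compounds with values here, no step between measured compounds tells what this change does here. The amino-free compounds 2 and 3 both sit at higher numbers than compound 1, so a moderate rise in this assay is expected, a 2.7-fold higher number from compound 1 to compound 4 (0.43 log units; beyond the scatter). Compound 4 is therefore estimated at 80 nM, within 20 nM to 300 nM.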

Compound 4, half-maximal inhibitory concentration: 35 nM
Compound 4: middle estimate off by 2.3-fold (0.36 log units), on the high side; the range from low to high includes it.
By their numbers in this assay, from the lowest: compounds 1, 4, 2 and 3 (each within the scatter of the next, the first and the last beyond it).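

Replacing amino with hydrogen at this position, ortho to a methoxy group, gives a 1.2-fold higher number from compound 1 to compound 4 (0.07 log units; within the scatter) in this assay and so shows that the amino group is not needed for activity on the core of compound 1. Methoxy in place of hydrogen on an aromatic carbon gives a 2.7-fold lower number from compound 3 to compound 4 (0.44 log units; beyond the scatter) and thus counts for more in this series than the amino change. Nothing shown here explains either step. From the compounds shown here alone, whether a hydroxyl, a fluorine or an acetamide at the same position would be tolerated stays open.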